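From Amide to Cyclopropyl Urea on a Sulfonate Scaffold

The source may hold more compounds than are shown below. What is called first, only, known or untested is meant among the compounds shown, and "the series" means these compounds.

Compound 1 `CCC(=O)Nc1ccc(S(=O)(=O)Oc2ccccc2I)cc1` gives 11000 nM in a functional assay on HT-29 cells (Homo sapiens) for antiproliferative activity, read by sulforhodamine B assay, with a stated time of 48 h (a higher number here means a weaker inhibitor, a lower number a stronger inhibitor), the highest of the two numbers at hand. Compound 2 `CCCCCNC(=O)Nc1ccc(S(=O)(=O)Oc2ccccc2C(C)C)cc1` gives 4900 nM in this assay; the two compounds differ in more than one place, so their values are only set side by side. Compound 3 `O=C(Nc1ccc(S(=O)(=O)Oc2ccccc2I)cc1)NC1CC1` is compound 1 with cyclopropylamino in place of ethyl on a carbonyl carbon. Among the compounds with values here, no single-point step between measured compounds is available to calibrate this change. Compound 3 is expected to give 6000 nM in this assay, with a range of 2500 nM to 15000 nM. The estimated step of a 1.8-fold lower number from compound 1 to compound 3 (0.26 log units; within the scatter) is a modest gain, barely beyond the scatter.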

Compound 3, half-maximal inhibitory concentration: 14000 nM
Beside the measured number, compound 3's estimate is 2.3-fold (0.37 log units) below it, within the range that was stated.
By their numbers in this assay, from the lowest: compound 2; then compounds 1 and 3 (each within the scatter of the next).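

In this assay, within the data shown here, the first single-change step on the shared core reads a 1.3-fold higher number from compound 1 to compound 3 (0.10 log units; within the scatter), so compound 1 and compound 3 cannot be told apart. At this carbonyl carbon, cyclopropylamino with its three-membered ring and hydrogen-bond donor therefore gives a value that matches that of ethyl. No available evidence bears on this result. Going by these compounds, it remains open whether dimethylamino or a longer chain on the same carbonyl carbon would separate from compound 1. A single step also leaves open how other groups at this carbon would read in this assay.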